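A Third Methoxy Group on the Ketone Ring

The source may hold more compounds than are shown below. What is called first, only, known or untested is meant among the compounds shown, and "the series" means these compounds.

Measured so far:
compound 1 `COc1ccc(-c2cc(/C=C/C(=O)c3cc(OC)c(OC)c(OC)c3)[nH]n2)cc1OC` — 1360 nM
compound 2 `COc1ccc(C(=O)/C=C/c2cc(-c3cc(OC)c(OC)c(OC)c3)n[nH]2)cc1OC` — 1440 nM

Of the compounds shown here, two have been tested in a functional assay on BT-549 cells (Homo sapiens) for inhibition, read by sulforhodamine B assay, with a stated time of 48 h; on this read-out higher numbers stand for weaker inhibition of growth and lower numbers for stronger inhibition of growth. Compound 1 gives 1360 nM and compound 2 gives 1440 nM. Compound 2 holds the higher of the two numbers, but the gap to compound 1 lies within the usual scatter, so the two compounds cannot be told apart on this read-out. Among the measured compounds shown here, no step between measured compounds that differ in one place is available, so nothing yet shows how a single substituent change moves the number.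

Compound 3 `COc1cc(C(=O)/C=C/c2cc(-c3cc(OC)c(OC)c(OC)c3)n[nH]2)cc(OC)c1OC` has not been measured. It differs from compound 2 in one place: methoxy in place of hydrogen on an aromatic carbon. For the measured compounds named here, with no measured step of this kind to lean on, the expectation rests on the two values alone. Compound 3 is expected to give about 900 nM in this assay, with a range from 300 nM to 3000 nM. The expected step of a 1.6-fold lower number from compound 2 to compound 3 (0.20 log units; within the scatter) is a small move toward stronger inhibition of growth, not clearly beyond the scatter.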

Compound 3, concentration for 50% growth inhibition: 1570 nM
Beside the measured number, compound 3's estimate is 1.7-fold (0.24 log units) below it; measured number inside the range.
By their numbers in this assay, from the lowest: compounds 1, 2 and 3 (each within the scatter of the next).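

In this assay, methoxy in place of hydrogen on an aromatic carbon, ortho to a methoxy group, gives a 1.1-fold higher number from compound 2 to compound 3 (0.04 log units; within the scatter), and the same kind of replacement gives a 1.2-fold higher number from compound 1 to compound 3 (0.06 log units; within the scatter). Among the compounds shown here, these are the first one-place steps, and both lie within the scatter, so adding this methoxy to either earlier compound produces no change that can be read on this measure of growth inhibition. No measurement at hand accounts for this flat result.

The compounds shown do not reveal how an amine, a hydroxyl or a longer alkoxy chain at this carbon would read, as methoxy is the only group seen here in place of hydrogen. They also leave open whether the same flat picture would hold in any other cell line.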